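The compounds below may be only part of what the source reports. "The series", "measured", "known", "first", "only" and "open" are said of these compounds alone.

Three compounds share one core and differ only in the ring at the end of the propoxy chain. In a functional assay on HepG2 cells (Homo sapiens) for antiproliferative activity, read by MTT assay, with a stated time of 72 h (on this read-out lower numbers stand for stronger inhibition and higher numbers for weaker inhibition), compound 1 `COc1cc2c(Nc3ccc(C#N)cc3)ncnc2cc1OCCCN1CCCCC1` gives 20700 nM, compound 2 `COc1cc2c(Nc3ccc(C#N)cc3)ncnc2cc1OCCCN1CCC(CO)CC1` gives 61800 nM, and compound 3 `COc1cc2c(Nc3ccc(C#N)cc3)ncnc2cc1OCCCN1CCC(c2ccccc2)CC1` gives 4610 nM. Compound 3 thus has the lowest number of the three: it lies a 4.5-fold lower number from compound 1 to compound 3 (0.65 log units; beyond the scatter) and a 13-fold lower number from compound 2 to compound 3 (1.13 log units; beyond the scatter), both beyond the scatter, whereas compound 2 sits furthest with a 3.0-fold higher number from compound 1 to compound 2 (0.48 log units; beyond the scatter).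

Compound 4 `COc1cc2c(Nc3ccc(C#N)cc3)ncnc2cc1OCCCN1CCc2ccccc2C1` carries 1,2,3,4-tetrahydroisoquinolin-2-yl in place of 4-phenylpiperidin-1-yl on a saturated chain carbon, three bonds along the chain from an oxygen on an aromatic ring. Within the data shown here, no measured step reproduces this change exactly. The two steps that bear on it are those in which a phenyl took the place of hydrogen or of hydroxymethyl on a saturated ring carbon, giving the modest lowering from compound 1 to compound 3 and the large lowering from compound 2 to compound 3. Compound 4 keeps an aromatic ring on the amine, now fused to the saturated ring rather than pendant, so a step smaller than either of those is expected, most likely a slight rise in this assay rather than a fall. Compound 4 is therefore estimated at 7500 nM, within a range of 2500 nM to 22000 nM, which would mean an expected step of a 1.6-fold higher number from compound 3 to compound 4 (0.21 log units; within the scatter).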

Compound 4, half-maximal inhibitory concentration: > 100000 nM
Compound 4: a limit, no number; the forecaster's own chance of this, stated with the estimate: 5%; middle value at least 13-fold (1.12 log units) away from the limit.
By their numbers in this assay, from the lowest: compound 3; then compound 1; then compound 2. At a limit, above all of these: compound 4.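

In this assay compound 4 gives > 100000 nM, which is a limit and not a number: the limit of > 100000 nM in this assay, at which 1 of the 4 values shown sits. At this place, on a saturated chain carbon, three bonds along the chain from an oxygen on an aromatic ring, putting 1,2,3,4-tetrahydroisoquinolin-2-yl in place of 4-phenylpiperidin-1-yl gives an at least 21-fold higher number from compound 3 to compound 4 (1.33 log units; beyond the scatter), so an aromatic ring on the amine does not by itself carry the lower number seen with the pendant phenyl. Set against the unsubstituted piperidin-1-yl group, the fused group gives an at least 4.8-fold higher number from compound 1 to compound 4 (0.68 log units; beyond the scatter), moving the number the opposite way from the pendant phenyl, while against 4-(hydroxymethyl)piperidin-1-yl it gives an at least 1.6-fold higher number from compound 2 to compound 4 (0.20 log units; that floor lies within the scatter), a floor that does not separate those two groups.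

The compounds shown leave open whether the step belongs to the fusion of the aromatic ring or to the smaller size of the entering group, and how far beyond the limit compound 4 lies. They also do not tell how a 4-benzylpiperidin-1-yl group or a morpholine ring on the same chain would read in this assay.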